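This account rests on a few compounds, and the source may have more. Where it says the series, first, only, none or still open, it means among the compounds named here.

In a functional assay on NALM-6 cells (Homo sapiens) for cytotoxicity, with a stated time of 72 h (on this read-out higher numbers stand for an effect only at larger amounts of compound and lower numbers for an effect already at smaller amounts), compound 1 (`C=C[C@@](C)(/C=C/c1ccc(Nc2ccccc2)cc1)CCC=C(C)C`) gives > 43400 nM and this is a limit, not a number. Compound 2 (`C=C[C@@](C)(/C=C/c1ccc(Nc2ccc(F)cc2)cc1)CCC=C(C)C`) gives > 43400 nM in this assay and this too is a limit. Within the data shown here, compound 2 therefore has no number of its own, and the series so far comes down to the limit of > 43400 nM in this assay, at which 2 of the 2 values shown sit, with no readable value to anchor on.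

Compound 3 (`C=C[C@@](C)(/C=C/c1ccc(Nc2ccc(C(F)(F)F)cc2)cc1)CCC=C(C)C`) carries trifluoromethyl in place of fluoro on an aromatic carbon, para to a large group (trifluoromethyl in place of fluoro on an aromatic carbon). Among the measured compounds shown here, the one measured step that bears on this change, fluoro in place of hydrogen on an aromatic carbon, is a step that the two limits leave unreadable from compound 1 to compound 2 and gives no size to carry over, so no step beyond the scatter is expected in this assay and no direction is claimed. The estimated step is a step that the limit leaves unreadable from compound 2 to compound 3 and a further limit is the likeliest report. Compound 3 is expected at 45000 nM within an estimated range of 20000 nM to 90000 nM on this read-out.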

Compound 3, half-maximal effective concentration: > 43400 nM
Compound 3: only a limit was reported (the forecaster's own chance of this, stated with the estimate: 75%); the middle value is on the limit's open side.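

In this assay compound 3 gives > 43400 nM, which is a limit and not a number. No new step can be read from compound 3 to compound 1 or compound 2, and the series stays at a single limit: the limit of > 43400 nM in this assay, at which 3 of the 3 values shown sit.

The compounds shown leave open whether any change on the shared core gives a readable value.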